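From 3,4-dichlorophenyl to 2-nitrophenyl on a shared core

The source may report more compounds than this note shows. Statements on the series, on what has been measured and on what is new or still open speak of the compounds shown alone.

compound 1 `CC1=CC[C@H]2[C@H](CC[C@]2(C)O)C(C)(C)[C@@H]1CC[C@H]1[C@]2(C)CC[C@H](OC(=O)CCC(=O)O)C(C)(C)O[C@H]2CC[C@@]1(C)O` gives 27900 nM
compound 2 `COc1ccc(C(=O)O[C@H]2CC[C@]3(C)[C@H](CC[C@@](C)(O)[C@H]3CC[C@@H]3C(C)=CC[C@H]4[C@H](CC[C@]4(C)O)C3(C)C)OC2(C)C)cc1` gives 30600 nM
compound 3 `CC1=CC[C@H]2[C@H](CC[C@]2(C)O)C(C)(C)[C@@H]1CC[C@H]1[C@]2(C)CC[C@H](OC(=O)c3ccc(Cl)c(Cl)c3)C(C)(C)O[C@H]2CC[C@@]1(C)O` gives 8100 nM

In a functional assay on MDA-MB-231 cells (Homo sapiens) for antiproliferative activity, read by MTT assay, with a stated time of 72 h (on this read-out lower numbers stand for stronger inhibition and higher numbers for weaker inhibition), compound 3 has the lowest number of the three, with 8100 nM as its value. Compound 4 `CC1=CC[C@H]2[C@H](CC[C@]2(C)O)C(C)(C)[C@@H]1CC[C@H]1[C@]2(C)CC[C@H](OC(=O)c3ccccc3[N+](=O)[O-])C(C)(C)O[C@H]2CC[C@@]1(C)O` has not yet been measured. It carries 2-nitrophenyl in place of 3,4-dichlorophenyl on a carbonyl carbon and is otherwise the same.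

Three measured steps changed the group at this same place. Two of them ended on 3,4-dichlorophenyl and were modest: a 3.4-fold lower number from compound 1 to compound 3 (0.54 log units; beyond the scatter) and a 3.8-fold lower number from compound 2 to compound 3 (0.58 log units; beyond the scatter) in each case. The third, between the other two groups, was a 1.1-fold higher number from compound 1 to compound 2 (0.04 log units; within the scatter) and so showed no real change. Within the data shown here, no measured compound carries a nitro group, so these steps offer only a rough guide. Moving away from 3,4-dichlorophenyl is therefore expected to raise the number modestly, with an estimated 2.3-fold higher number from compound 3 to compound 4 (0.37 log units; beyond the scatter) in this assay as the likely size. For compound 4 the estimated value is 19000 nM with 7000 nM to 40000 nM as the expected range.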

Compound 4, half-maximal inhibitory concentration: 38700 nM
Compound 4: the middle estimate sits 2.0-fold (0.31 log units) below what was measured; low and high end bracket the measured number.
By their numbers in this assay, from the lowest: compound 3; then compounds 1, 2 and 4 (each within the scatter of the next).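

In this assay, swapping 3,4-dichlorophenyl for 2-nitrophenyl loses the advantage of compound 3, giving a 4.8-fold higher number from compound 3 to compound 4 (0.68 log units; beyond the scatter) in a step larger than any seen before at this position. Compound 4 also sits within the scatter of the other two compounds, with a 1.3-fold higher number from compound 2 to compound 4 (0.10 log units; within the scatter) and a 1.4-fold higher number from compound 1 to compound 4 (0.14 log units; within the scatter) in the same range, so 2-nitrophenyl, 4-methoxyphenyl and 2-carboxyethyl cannot be told apart here. Among these four compounds, an aromatic ring on the carbonyl carbon is therefore not enough for the lower number: compound 3 has one, but so do compound 2 and compound 4, and both go against that idea.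

Nothing available explains why 3,4-dichlorophenyl stands apart. Still open, on these data alone, is whether a plain phenyl, a 4-chlorophenyl or a group carrying an amine would keep the number of compound 3 or fall back with the others.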